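Swapping the halogenated ring: from compound 1 to compound 4

The source may report more compounds than this note shows. Statements on the series, on what has been measured and on what is new or still open speak of the compounds shown alone.

Measured so far:
compound 1 `N/C(CC(O)c1cccc2ccccc12)=N\N=C\c1ccc(Cl)c(Cl)c1` with 16000 nM
compound 2 `CCOc1cc(/C=N/N=C(\N)CC(O)c2cccc3ccccc23)ccc1O` with 4200 nM
compound 3 `Cc1ccc(/C=N/N=C(\N)CC(O)c2ccc3ccccc3c2)cc1` with 103000 nM

Of the compounds shown here, three sharing the same hydrazone-linked core have been tested in an ADME assay on L6 cells (Rattus norvegicus) for cytotoxicity, read by resazurin assay, with a stated time of 72 h; a higher number here means a weaker inhibitor, a lower number a stronger inhibitor. Compound 1 stands second highest of the three numbers. Compound 2 gives a lower number, and that gap lies beyond the usual scatter. Compound 3 gives a higher number than compound 1, again beyond the scatter, so compound 3 is the weakest inhibitor of the three on these numbers.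

Compound 4 `N/C(CC(O)c1cccc2ccccc12)=N\N=C\c1ccc(F)cc1F` has not yet been measured in this assay. It differs from compound 1 in one place: 2,4-difluorophenyl in place of 3,4-dichlorophenyl on a carbon with a double bond to nitrogen. Among the compounds with values here, no pair of measured compounds with a single difference is available, so the size of this step cannot be read from the data. A modest movement toward a higher number is expected for compound 4, roughly at the edge of the scatter, a 1.9-fold higher number from compound 1 to compound 4 (0.27 log units; within the scatter). The estimate for compound 4 in this assay is 30000 nM, with an expected range from 10000 nM to 90000 nM.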

Compound 4, half-maximal inhibitory concentration: 4200 nM
Estimate against measurement, compound 4: 7.1-fold (0.85 log units) above, outside the stated range (below it).
By their numbers in this assay, from the lowest: compounds 2 and 4 (each within the scatter of the next); then compound 1; then compound 3.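

In this assay, within the data shown here, the exchange gives the first single-place step, a 3.8-fold lower number from compound 1 to compound 4 (0.58 log units; beyond the scatter), so this position can move the number beyond the scatter, here toward a stronger inhibitor. The two groups match in heavy-atom count, aromatic ring, hydrogen-bond donors and acceptors, and net charge, so this step arises with a change that leaves those counts untouched and alters only the halogen and its placement in the group. Nothing available explains the step.

The compounds shown leave open whether the halogen or its placement carries the step, and a 2,4-dichlorophenyl group at this place would separate the two. Going by these compounds, how a group of another kind, such as an aminophenyl or a carboxyphenyl group, would read at this place also remains open.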